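The source may hold more compounds than are shown below. What is called first, only, known or untested is meant among the compounds shown, and "the series" means these compounds.

Working notes on a small set of fused bicyclic compounds tested in a functional assay on KB cells (Homo sapiens) for inhibition; on this read-out higher numbers stand for weaker inhibition and lower numbers for stronger inhibition. Compound 1 `CNc1c(C#N)c2c(N)ncnc2n1COCCOC` returns only a limit of the assay in this assay, > 100000 nM. Compound 2 `COCCOCn1c(N)c(C(N)=O)c2c(N)ncnc21` likewise sits at a limit of the assay in this assay, > 100000 nM. For the measured compounds named here, compound 3 `CCOCn1cc(C(=N)S)c2c(N)ncnc21` is the one member of the set that gives a number in this assay, 60000 nM. Since the two other entries are limits rather than numbers, compound 3 stands alone as the only measured point and carries no rank relative to compound 1 or compound 2. What can be said of the measured entries amounts to the limit of > 100000 nM in this assay, at which 2 of the 3 values shown sit, and nothing more.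

Compound 4 `CCOCn1c(N)c(C(=N)S)c2c(N)ncnc21` is not yet measured. It differs from compound 3 by amino in place of hydrogen on an aromatic carbon. Going by the values given here, no step between measured compounds is available to calibrate this change; compound 1 and compound 2 show only limits, and their other groups differ from those of compound 3, so only the bare values can be read. For compound 4 the expected outcome in this assay is a step of a 1.7-fold higher number from compound 3 to compound 4 (0.22 log units; within the scatter) towards weaker inhibition, beyond the usual scatter but not large, with a real chance that only a limit is returned. The estimated value for compound 4 is 100000 nM, range 30000 nM to 300000 nM.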

Compound 4, half-maximal inhibitory concentration: > 320000 nM
Compound 4 was reported as a limit (the forecaster's own chance of this, stated with the estimate: 60%); middle value at least 3.2-fold (0.50 log units) away from the limit.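

In this assay, for the compounds shown here, amino in place of hydrogen on an aromatic carbon of the five-membered aromatic ring, next to the ring nitrogen, gives an at least 5.3-fold higher number from compound 3 to compound 4 (0.72 log units; beyond the scatter), the first step in this set that isolates one change and so the first direct reading of this position. Compound 4 returns only a limit of the assay, so the step shows a direction towards weaker inhibition and a minimum size, with its full size unknown: the limit of > 320000 nM in this assay, at which 1 of the 4 values shown sits. Compounds 1 and 2 could not show this, as both also return limits and differ from compound 3 in more than one place, whereas the present pair shows that with the ethoxymethyl group held constant, this single exchange is enough to move the read-out beyond the scatter.

From the compounds shown here alone, only hydrogen and amino are compared directly at this position, so it remains open whether the weakening is particular to amino or would also follow from another group there, such as a methyl group or a chlorine atom. Going by these compounds, the effect of the same exchange with a longer chain in place of ethoxymethyl, or with a nitrile or a carboxamide in place of the group of 3 heavy atoms, also remains open.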